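Replacing ethyl with chloro in compound 2

A few compounds are considered here, and "the series" means these few. Any claim that something is new, unique, unknown or untested is made for them only; others in the source may bear on it.

Values in a functional assay on MCF7 cells (Homo sapiens) for inhibition, read by MTT assay (a lower number here means a stronger inhibitor, a higher number a weaker inhibitor), are:
Compound 1 `COc1cc2ncnc(Nc3ccc(NC(=O)c4ccccc4C)cc3)c2cc1OC` gives 21000 nM
Compound 2 `CCc1ccc(C(=O)Nc2ccc(Nc3ncnc4cc(OC)c(OC)cc34)cc2)cc1` gives 65000 nM
Compound 3 `COc1cc2ncnc(Nc3ccc(NC(=O)c4cccc(F)c4)cc3)c2cc1OC` gives 13600 nM

Compound 2 has the highest number of the three, which makes it the weakest inhibitor here. Compound 4 `COc1cc2ncnc(Nc3ccc(NC(=O)c4ccc(Cl)cc4)cc3)c2cc1OC` differs from it in one place chloro in place of ethyl on an aromatic carbon with chloro in place of ethyl on an aromatic carbon, para to a large group. Within the data shown here, no measured step makes this exact swap. Three steps change the phenyl group on the carbonyl carbon: a 3.1-fold higher number from compound 1 to compound 2 (0.49 log units; beyond the scatter) and a 4.8-fold lower number from compound 2 to compound 3 (0.68 log units; beyond the scatter) are modest, while a 1.5-fold lower number from compound 1 to compound 3 (0.19 log units; within the scatter) stays within the scatter. Compound 2 therefore stands apart from both neighbours, so a modest drop in this assay is expected. The expected change is a 2.6-fold lower number from compound 2 to compound 4 (0.41 log units; beyond the scatter) as a rough estimate. Compound 4 is estimated at 25000 nM (expected range 9000 nM to 60000 nM).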

Compound 4, half-maximal inhibitory concentration: 30000 nM
Compound 4: the middle estimate sits 1.2-fold (0.08 log units) below what was measured; the measured number falls inside the stated range.
By their numbers in this assay, from the lowest: compounds 3, 1 and 4 (each within the scatter of the next, the first and the last beyond it); then compound 2.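

In this assay, among these compounds, swapping the ethyl of the 4-ethylphenyl group for chloro gives a 2.2-fold lower number from compound 2 to compound 4 (0.34 log units; beyond the scatter) and offers the first direct look at a change of this one group on the ring. The 4-chlorophenyl compound shows a 2.2-fold higher number from compound 3 to compound 4 (0.34 log units; beyond the scatter) against the 3-fluorophenyl compound, yet a 1.4-fold higher number from compound 1 to compound 4 (0.15 log units; within the scatter) leaves it indistinguishable from the 2-methylphenyl compound. No measurement here offers an explanation for these steps. From the compounds shown here alone, whether an amine or a carboxylic acid in place of chloro would give a lower or higher number remains open.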